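The source may report more compounds than this note shows. Statements on the series, on what has been measured and on what is new or still open speak of the compounds shown alone.

Going by the values given here, in an assay on isolated protein (kidney, strain Wistar) for displacement of a labelled ligand from Translocator protein (Rattus norvegicus), read by scintillation counting, with a stated time of 90 min (a higher number here means a weaker inhibitor, a lower number a stronger inhibitor), compound 1 `CCN(CC)C(=O)Cc1c(-c2ccc(OC(C)C)cc2)nn2c(C)cc(C)nc12` gives 2.2 nM, the second highest of the three numbers measured so far. Compound 2 `CCN(CC)C(=O)Cc1c(-c2ccc(OCC3CC3)cc2)nn2c(C)cc(C)nc12` gives 3 nM in this assay, and compound 3 `CCN(CC)C(=O)Cc1c(-c2ccc(OCc3cccc(F)c3)cc2)nn2c(C)cc(C)nc12` gives 0.47 nM. The change from compound 1 to compound 2, cyclopropylmethyl in place of isopropyl on an oxygen on an aromatic ring, gave a 1.4-fold higher number from compound 1 to compound 2 (0.13 log units; within the scatter), whereas 3-fluorobenzyl in the same place gave a 4.7-fold lower number from compound 1 to compound 3 (0.67 log units; beyond the scatter).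

Compound 4 `CCN(CC)C(=O)Cc1c(-c2ccc(OCc3ccc(C(F)(F)F)cc3)cc2)nn2c(C)cc(C)nc12` differs from compound 1 by 4-(trifluoromethyl)benzyl in place of isopropyl on an oxygen on an aromatic ring. The step that bears most directly on it is a 4.7-fold lower number from compound 1 to compound 3 (0.67 log units; beyond the scatter), since that also placed a substituted benzyl group on the oxygen; the step of a 1.4-fold higher number from compound 1 to compound 2 (0.13 log units; within the scatter) shows that a small chain in that place leaves the number unchanged. A modestly lower number is therefore expected for compound 4, a 3.7-fold lower number from compound 1 to compound 4 (0.56 log units; beyond the scatter). The estimate for compound 4 is 0.6 nM, with a range from 0.2 nM to 2 nM.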

Compound 4, inhibition constant: 1.6 nM
Estimate against measurement, compound 4: 2.7-fold (0.43 log units) below; the measured number falls inside the stated range.
By their numbers in this assay, from the lowest: compound 3; then compounds 4, 1 and 2 (each within the scatter of the next).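

In this assay, a benzyl group on the oxygen does not by itself bring the lower number: 4-(trifluoromethyl)benzyl in place of isopropyl gives only a small shift (a 1.4-fold lower number from compound 1 to compound 4 (0.14 log units; within the scatter)), while the change from 3-fluorophenyl to 4-(trifluoromethyl)phenyl on the same chain carbon gives a modest rise (a 3.4-fold higher number from compound 3 to compound 4 (0.53 log units; beyond the scatter)). The substituent on the benzyl ring therefore matters here, although the step from cyclopropyl also stays small (a 1.9-fold lower number from compound 2 to compound 4 (0.27 log units; within the scatter)). No measurement shown accounts for this difference. Since that change alters both the substituent and its place on the ring, the two effects remain unseparated. Plain benzyl, 4-fluorobenzyl and a benzyl ring bearing an amine are left open.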